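A few compounds are considered here, and "the series" means these few. Any claim that something is new, unique, unknown or untested is made for them only; others in the source may bear on it.

Measured so far:
compound 1 `COc1cc2c(cc1O)CCC(C)(CC(=O)O)O2` — 100%
compound 2 `COc1cc2c(cc1O)CCC(C)(CC(=O)N[C@H](C(=O)O)C(C)C)O2` — 79.1%

In an ADME assay on SH-SY5Y cells (Homo sapiens) for cytotoxicity, read by MTT assay, with a stated time of 24 h, tested at 3.1 uM (a higher number here means a weaker effect of the compound at the concentration tested, a lower number a stronger effect), compound 2 gives 79.1%, the lowest of the two numbers. Compound 1 gives 100%. Within the data shown here, the one measured step is a number 20.9 percentage points lower from compound 1 to compound 2 (beyond the scatter).

Compound 3 `COc1cc2c(cc1O)CCC(C)(CC(N)=O)O2` is not yet measured. (hydrogen in place of 1-carboxy-2-methylpropyl on an amide-type nitrogen). The measured step bears on this change only loosely: it added the 1-carboxy-2-methylpropyl group that now leaves, but there hydroxy was exchanged for (1-carboxy-2-methylpropyl)amino on the carbonyl carbon, whereas here the amino is kept and only the substituent on its nitrogen is lost. Among the measured compounds shown here, compound 3 therefore sits between compound 1 and compound 2 in structure, and a number between their two values is the plain expectation, with no measured step fixing its exact size. The expected step is a number 10.9 percentage points higher from compound 2 to compound 3 (beyond the scatter), a rise in this assay. Compound 3 is estimated at 90%, within 72% to 104%.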

Compound 3, a percentage reported as activity, at one concentration (the size of the read-out at that concentration, not a potency): 100%
Estimate against measurement, compound 3: 10 percentage points below; the measured number falls inside the stated range.
By their numbers in this assay, from the lowest: compound 2; then compounds 1 and 3 (each within the scatter of the next).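

In this assay the loss of the 1-carboxy-2-methylpropyl group from the amide-type nitrogen gives a number 20.9 percentage points higher from compound 2 to compound 3 (beyond the scatter) and so ties the lower number to that substituent, not to the amide-type nitrogen as such. Amino in place of hydroxy on the carbonyl carbon gives no change at the digits printed from compound 1 to compound 3 (within the scatter) and thereby splits the earlier exchange into two parts, of which only the substituent on nitrogen shows in this read-out. Nothing measured here explains the step.

On these data alone, whether the carboxylic acid within the 1-carboxy-2-methylpropyl group is needed for the lower number stays open, and a plain 2-methylpropyl group or a methyl ester on the same nitrogen would address that. The compounds shown also leave open how a shorter chain, such as a methyl group on that nitrogen, would read.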